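A few compounds are considered here, and "the series" means these few. Any claim that something is new, unique, unknown or untested is made for them only; others in the source may bear on it.

For the measured compounds named here, in a functional assay on A-431 cells (Homo sapiens) for cytotoxicity (a lower number here means that less compound is needed, a higher number that more compound is needed for the effect), compound 2 `COC1=C(C)C(=O)/C(=C(O)/C=C/c2cccc(OC)c2)C(=O)C1(C)C` gives 4.5 ug/mL, the lowest of the two numbers known so far. Going by the values given here, its only neighbour, compound 1 `COC1=C(C)C(=O)/C(=C(O)/C=C/c2ccc(Br)cc2)C(=O)C1(C)C`, gives 9 ug/mL in this assay, and the step of a 2.0-fold lower number from compound 1 to compound 2 (0.30 log units; within the scatter) lies within the scatter. Compound 3 `C=Cc1ccccc1/C=C/C(O)=C1/C(=O)C(C)=C(OC)C(C)(C)C1=O` differs from compound 2 as follows: 2-vinylphenyl in place of 3-methoxyphenyl on a double-bonded chain carbon bound to a double-bonded chain carbon. Among the compounds with values here, the one measured step also exchanged the group on a double-bonded chain carbon bound to a double-bonded chain carbon and barely moved the number, so the expected step of a 1.2-fold higher number from compound 2 to compound 3 (0.09 log units; within the scatter) stays within the scatter. Compound 3 is therefore estimated at 5.5 ug/mL in this assay, with a range from 2.5 ug/mL to 12 ug/mL.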

Compound 3, concentration for half-maximal effect: 2.6 ug/mL
For compound 3 the middle estimate is 2.1-fold (0.33 log units) above the measured one, and the stated range covers the measured number.
By their numbers in this assay, from the lowest: compounds 3, 2 and 1 (each within the scatter of the next, the first and the last beyond it).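

In this assay, the change to 2-vinylphenyl gives a 3.5-fold lower number from compound 1 to compound 3 (0.54 log units; beyond the scatter), the first step shown at this position to lie beyond the scatter, so the group on this double-bonded chain carbon can shift the number, though modestly. By contrast, a 1.7-fold lower number from compound 2 to compound 3 (0.24 log units; within the scatter) does not separate 2-vinylphenyl from 3-methoxyphenyl. No measurement here accounts for either step. Going by these compounds, all three compounds carry a substituted phenyl group at this position, so the effect of an amine, a carboxylic acid or a longer chain there remains open.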